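This account rests on a few compounds, and the source may have more. Where it says the series, first, only, none or still open, it means among the compounds named here.

Measured so far in an ADME assay on tissue (MDA-MB-231 cells, Homo sapiens) for pharmacokinetics; on this read-out higher numbers stand for a longer-lived compound and lower numbers for a shorter-lived compound:

- compound 1, `N[C@@H](CC(=O)OC[C@H]1O[C@@H](n2cc(F)c(=O)[nH]c2=O)C[C@@H]1O)C(=O)O`: 0.185 h
- compound 2, `CC(C)[C@H](N)C(=O)OC[C@H]1O[C@@H](n2cc(F)c(=O)[nH]c2=O)C[C@@H]1O`: 0.255 h
- compound 3, `N[C@@H](CC(=O)O[C@H]1C[C@H](n2cc(F)c(=O)[nH]c2=O)O[C@@H]1CO)C(=O)O`: 0.322 h

Compounds 1 and 2 share one core; compound 3 carries the same atoms joined differently, and the difference between the two cores is not broken down here. Within the first core the only change is 1-amino-2-methylpropyl in place of 2-amino-2-carboxyethyl on a carbonyl carbon, and that step reads a 1.4-fold higher number from compound 1 to compound 2 (0.14 log units; within the scatter), so the two numbers sit within the usual scatter of one another. Compound 3 stands with the highest of the three numbers, but its gaps to compound 2 and to compound 1 are both within the scatter, so no order among the three is claimed.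

Compound 4, `CC(C)[C@H](N)C(=O)O[C@H]1C[C@H](n2cc(F)c(=O)[nH]c2=O)O[C@@H]1CO`, has not yet been measured in this assay. It differs from compound 3 by 1-amino-2-methylpropyl in place of 2-amino-2-carboxyethyl on a carbonyl carbon, the same change that turned compound 1 into compound 2, made at a place described in the same words. Within the data shown here, with only that one earlier step to rest on, compound 4 is expected to show a 1.4-fold higher number from compound 3 to compound 4 (0.15 log units; within the scatter) relative to compound 3, a small step that is within the scatter, because the matching move from compound 1 to compound 2 gave a 1.4-fold higher number from compound 1 to compound 2 (0.14 log units; within the scatter). On that basis compound 4 is estimated at 0.45 h in this assay, with a plausible span from 0.25 h to 0.8 h.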

Compound 4, half-life: 0.248 h
The estimate for compound 4 lay 1.8-fold (0.26 log units) above the measured number, outside the stated range (below it).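

In this assay, 1-amino-2-methylpropyl in place of 2-amino-2-carboxyethyl on a carbonyl carbon reads a 1.3-fold lower number from compound 3 to compound 4 (0.11 log units; within the scatter). Set beside the same change on the other core, the two steps do not separate: the same change on two cores in this assay, a 1.4-fold higher number (0.14 log units; within the scatter) from compound 1 to compound 2 and a 1.3-fold lower number (0.11 log units; within the scatter) from compound 3 to compound 4, 1.8-fold (0.25 log units) apart, within the scatter of two such steps. Among these compounds, the opposite signs of the two steps therefore give no evidence that the core alters the outcome of this change, but they also do not show that the change carries over reliably, since neither step on its own stands clear of the scatter and the half-life readings on both cores remain compatible with no measurable step at all.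

The compounds shown leave open whether any replacement on this carbonyl carbon can produce a step beyond the scatter, as both groups compared here carry an amine and a group such as a longer alkyl chain with no amine, or an aromatic ring, is not among them. Among the compounds shown here, with only two matched steps available, it also remains open whether a real dependence on the core, too small to resolve here, lies hidden within that scatter.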